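The compounds below may be only part of what the source reports. "The series", "measured", "known", "first", "only" and "open" are said of these compounds alone.

Of the compounds shown here, two so far carry a number in a functional assay on MCF7 cells (Homo sapiens) for inhibition, read by MTT assay, with a stated time of 48 h; a lower number here means a stronger inhibitor, a higher number a weaker inhibitor. Compound 1 `O=C(C=CNc1cc(-c2ccccc2)nn1-c1ccccc1)c1ccc(Cl)cc1` gives 8070 nM in this assay, the higher of the two values. Compound 2 `COc1ccc(-c2nc3c(c(-c4ccccc4)nn3-c3ccccc3)c(-c3ccc(N4CCCCC4)cc3)c2C#N)cc1` gives 2760 nM in this assay; the gap between the two is beyond the scatter, so compound 1 stands as the weaker of the pair. The two structures differ in many places at once, so the pair shows only its two values and supports no reading of any single change.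

Compound 3 `COc1ccc(C(=O)C=CNc2cc(-c3ccccc3)nn2-c2ccccc2)cc1` has not been measured. It keeps the core of compound 1 and differs from it in one place: methoxy in place of chloro on an aromatic carbon. For the measured compounds named here, no measured pair shows this exchange, so there is no precedent here for its size or direction. Given the lack of any such reference, the expected step is a 1.1-fold lower number from compound 1 to compound 3 (0.03 log units; within the scatter), no larger than the scatter in either direction. Compound 3 is therefore expected to give about 7500 nM in this assay, within a range from 2500 nM to 22000 nM.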

Compound 3, half-maximal inhibitory concentration: 1290 nM
Beside the measured number, compound 3's estimate is 5.8-fold (0.76 log units) above it, outside the stated range (below it).
By their numbers in this assay, from the lowest: compound 3; then compound 2; then compound 1.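

In this assay the exchange of chloro for methoxy on an aromatic carbon, para to a large group, is the only single-place change shown so far, and it gives a 6.3-fold lower number from compound 1 to compound 3 (0.80 log units; beyond the scatter). This position therefore responds to the group it carries, and 4-methoxyphenyl stands ahead of 4-chlorophenyl at the (4-chlorophenyl)carbonyl end of the molecule, though this rests on one pair alone. Nothing at hand explains the size or direction of this step.

On these data alone, it remains open whether the step belongs to methoxy itself or whether other groups at this carbon would match or pass it, such as hydroxy, ethoxy as a longer chain, dimethylamino as an amine, or plain hydrogen as the unsubstituted parent. It is also open whether the same exchange carries the same step on another core: compound 2 holds a 4-methoxyphenyl on a different core, and no chloro partner for it stands among the compounds shown.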